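Cyclopropyl to 4-Bromobenzyl on the Amine Nitrogen

The source may hold more compounds than are shown below. What is called first, only, known or untested is meant among the compounds shown, and "the series" means these compounds.

Compound 1, `COc1cc(Oc2cccc(Nc3ccccc3)c2)cc(OC)c1CNC(C)C`, in a functional assay on HCT-15 cells (Homo sapiens) for inhibition, read by MTT assay, with a stated time of 72 h (on this read-out higher numbers stand for weaker inhibition and lower numbers for stronger inhibition), gives > 20000 nM, which is a limit of the assay and not a number.
Compound 2, `COc1cc(Oc2cccc(Nc3ccccc3)c2)cc(OC)c1CNC1CC1`, in this assay gives 6140 nM.

Compound 2 holds the only number shown in this assay; the other value is a limit. Going by the values given here, the single measured step, an at least 3.2-fold lower number from compound 1 to compound 2 (0.51 log units; beyond the scatter), is the sole guide, and its size rests on (the limit of > 20000 nM in this assay, at which 1 of the 2 values shown sits), so only its lower bound is known. The change now followed is compound 3, `COc1cc(Oc2cccc(Nc3ccccc3)c2)cc(OC)c1CNCc1ccc(Br)cc1`, which differs from compound 2 by 4-bromobenzyl in place of cyclopropyl on an amine nitrogen. That measured step swapped one small group for another on the same amine nitrogen, whereas here a 4-bromobenzyl enters; the measured step therefore bears on it only loosely, and no value shown tells how a benzyl group on this nitrogen behaves. Compound 3 is expected to stay close to compound 2, with a 1.5-fold lower number from compound 2 to compound 3 (0.19 log units; within the scatter). Compound 3 is thus estimated at 4000 nM, within 1000 nM to 20000 nM.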

Compound 3, half-maximal inhibitory concentration: 5410 nM
Compound 3: middle estimate off by 1.4-fold (0.13 log units), on the low side; the measured number falls inside the stated range.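

In this assay, the result shows that this amine nitrogen can carry a far larger group than the small ones seen so far and still give a number in the same range: a 1.1-fold lower number from compound 2 to compound 3 (0.05 log units; within the scatter), even though 4-bromobenzyl brings 8 heavy atoms and a six-membered aromatic ring where cyclopropyl had 3 heavy atoms and a three-membered ring. Compound 1 stays at > 20000 nM, which is a limit and not a number. Both ring-bearing groups therefore give measured numbers, with compound 1 and its isopropyl as the one case against them, and the step of an at least 3.6-fold lower number from compound 1 to compound 3 (0.56 log units; beyond the scatter) can be read only as a lower bound: the limit of > 20000 nM in this assay, at which 1 of the 3 values shown sits.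

The compounds shown leave open whether the bromine contributes anything, which a plain benzyl or a 4-chlorobenzyl on the same nitrogen would address. They also leave open how a longer chain such as phenethyl, a larger ring such as cyclohexyl, or a primary amine with no group on this nitrogen would read out in this assay.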